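This account rests on a few compounds, and the source may have more. Where it says the series, first, only, none or still open, it means among the compounds named here.

Four compounds share one core and differ in a single group on an aromatic carbon: compound 1 `Clc1ccc2[nH]c(-c3cn(-c4ccccc4)nc3-c3ccccc3)nc2c1`, compound 2 `Brc1ccc2[nH]c(-c3cn(-c4ccccc4)nc3-c3ccccc3)nc2c1`, compound 3 `Cc1ccc2[nH]c(-c3cn(-c4ccccc4)nc3-c3ccccc3)nc2c1` and compound 4 `FC(F)(F)c1ccc2[nH]c(-c3cn(-c4ccccc4)nc3-c3ccccc3)nc2c1`. For the measured compounds named here, in a functional assay on MCF7 cells (Homo sapiens) for antiproliferative activity, read by MTT assay, with a stated time of 48 h (a higher number here means a weaker inhibitor, a lower number a stronger inhibitor), compound 1 gives 1960 nM, compound 2 gives 830 nM and compound 3 gives 5940 nM, the highest number so far, which makes compound 3 the weakest measured. Compound 4 carries trifluoromethyl in place of methyl on an aromatic carbon. Going by the values given here, no measured compound has trifluoromethyl, so the evidence is indirect. Methyl gave the higher number in both steps that introduce it, a 3.0-fold higher number from compound 1 to compound 3 (0.48 log units; beyond the scatter) and a 7.2-fold higher number from compound 2 to compound 3 (0.85 log units; beyond the scatter), while bromo and chloro differ by a 2.4-fold lower number from compound 1 to compound 2 (0.37 log units; beyond the scatter). In this assay a modest step to a lower number is therefore expected, a 3.3-fold lower number from compound 3 to compound 4 (0.52 log units; beyond the scatter). Compound 4 is estimated at 1800 nM, with an expected range of 600 nM to 5500 nM.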

Compound 4, half-maximal inhibitory concentration: 2660 nM
Estimate against measurement, compound 4: 1.5-fold (0.17 log units) below; the range from low to high includes it.
By their numbers in this assay, from the lowest: compound 2; then compounds 1 and 4 (each within the scatter of the next); then compound 3.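

In this assay, trifluoromethyl at this position gives a stronger inhibitor than methyl (a 2.2-fold lower number from compound 3 to compound 4 (0.35 log units; beyond the scatter)) but a weaker one than bromo (a 3.2-fold higher number from compound 2 to compound 4 (0.51 log units; beyond the scatter)). It cannot be told apart from chloro (a 1.4-fold higher number from compound 1 to compound 4 (0.13 log units; within the scatter)), so the new group lands in the middle of the series, level with chloro, rather than at either end. No measurement here bears on why the groups fall in this order. Still open, from the compounds shown here alone, is how a group of a different kind at this position, such as an amine, a carboxylic acid or a longer chain, would compare with these four.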